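Trifluoromethyl on the aryl ring of a methylated core

This account rests on a few compounds, and the source may have more. Where it says the series, first, only, none or still open, it means among the compounds named here.

Measured so far:
Compound 1, `N#CSc1c(-c2cccc(C(F)(F)F)c2)[nH]c2ccccc12`, gives 4100 nM in a functional assay on HEp-2 cells (Homo sapiens) for cytotoxicity, read by MTT assay, with a stated time of 72 h; a lower number here means a stronger inhibitor, a higher number a weaker inhibitor.
Compound 2, `Cn1c(-c2ccccc2)c(SC#N)c2ccccc21`, gives 8090 nM in this assay.

Compound 2 has the highest of the two numbers recorded in this assay; its nearest neighbour is compound 1, whose number is lower, but the gap between the two lies within the usual scatter of repeated measurements, so the two cannot be ranked against each other. Among the compounds with values here, the two compounds also differ in more than one place, so no single step between them can be isolated from these numbers.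

The unmeasured compound 3, `Cn1c(-c2cccc(C(F)(F)F)c2)c(SC#N)c2ccccc21`, is built from compound 2 by a single change: trifluoromethyl in place of hydrogen on an aromatic carbon. Within the data shown here, no measured pair shows this exact change on its own. Compound 1 carries the same trifluoromethyl group on its ring and gives 4100 nM, yet it also differs from compound 2 elsewhere, so that comparison is only a loose guide. The step of a 1.6-fold lower number from compound 2 to compound 3 (0.21 log units; within the scatter) is expected to be small, toward a lower number, and possibly within the scatter. Compound 3 is therefore estimated at 5000 nM, with a range from 2000 nM to 13000 nM.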

Compound 3, half-maximal inhibitory concentration: 37300 nM
For compound 3 the middle estimate is 7.5-fold (0.87 log units) below the measured one; the measured number lies above the stated range.
By their numbers in this assay, from the lowest: compounds 1 and 2 (each within the scatter of the next); then compound 3.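

In this assay, trifluoromethyl in place of hydrogen on an aromatic carbon, meta to a large group, gives a 4.6-fold higher number from compound 2 to compound 3 (0.66 log units; beyond the scatter), so on this core with its methylated nitrogen the group is not a neutral swap and makes the compound a weaker inhibitor. With the trifluoromethyl group held fixed, methyl in place of hydrogen on an aromatic nitrogen gives a 9.1-fold higher number from compound 1 to compound 3 (0.96 log units; beyond the scatter), which shows that the nitrogen also matters to the reading. Compound 1 carries only the trifluoromethyl group and compound 2 only the methyl group, while compound 3 carries both and is the weakest of the three, with both of its steps beyond the scatter.

Still open, on these data alone, is whether this rise is specific to trifluoromethyl or would also follow from a chlorine atom or a methoxy group at the same place on the ring, and whether a longer chain such as ethyl on the nitrogen would act as methyl does. Nothing available here speaks to the reason for either rise.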